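This account rests on a few compounds, and the source may have more. Where it says the series, first, only, none or still open, it means among the compounds named here.

Compound 1 `O=C(Nc1cccc(C(F)(F)F)c1)N[C@H]1CC[C@H](Oc2cccc(C(F)(F)F)c2)CC1` gives the lowest of the two numbers shown: in a functional assay on CRL2813 cells (Homo sapiens) for cytotoxicity, read by sulforhodamine B assay, with a stated time of 5 days (a lower number here means a stronger inhibitor, a higher number a weaker inhibitor), compound 1 gives 1300 nM, while compound 3 `O=C(Nc1ccccc1Br)N[C@H]1CC[C@H](Oc2ccc(F)cc2)CC1` sits higher in this assay at 7700 nM, a gap beyond the usual scatter. Compound 2 `O=C(Nc1ccccc1C(=O)O)N[C@H]1CC[C@@H](Oc2ccc(F)cc2)CC1` reaches only a limit of this assay, > 20000 nM, and so offers no number (the limit of > 20000 nM in this assay, at which 1 of the 3 values shown sits). Compound 4 `O=C(Nc1cccc(C(F)(F)F)c1)N[C@H]1CC[C@H](Oc2cccc(F)c2)CC1` has not yet been tested in this assay; it differs from compound 1 by fluoro in place of trifluoromethyl on an aromatic carbon. Among the compounds with values here, with no measured step of this kind among the compounds above, the estimate rests on compound 1 alone. A moderate rise from compound 1 to compound 4, a 2.3-fold higher number from compound 1 to compound 4 (0.36 log units; beyond the scatter), is expected, and compound 4 is estimated at 3000 nM, within 1000 nM to 10000 nM.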

Compound 4, half-maximal inhibitory concentration: 2400 nM
The estimate for compound 4 lay 1.3-fold (0.10 log units) above the measured number; measured number inside the range.
By their numbers in this assay, from the lowest: compounds 1 and 4 (each within the scatter of the next); then compound 3. At a limit, above all of these: compound 2.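

In this assay, replacing trifluoromethyl with fluoro on this aromatic carbon gives a 1.8-fold higher number from compound 1 to compound 4 (0.27 log units; within the scatter). Within the data shown here, this is the first measured step at this position, and it shows that the number holds within the scatter when trifluoromethyl, with its four heavy atoms, gives way to a single fluorine. Nothing shown here gives a reason for this result. The compounds shown leave open whether a nitrile, a methoxy group or an amine at this place would hold the number as well. They also leave open how the number responds to a change at any other position on this ring.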